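A few compounds are considered here, and "the series" means these few. Any claim that something is new, unique, unknown or untested is made for them only; others in the source may bear on it.

Measured so far:
Compound 1 `O=C(Nc1ccnc(Cl)c1)Nc1cc(Cl)nc(Cl)c1` gives 16100 nM
Compound 2 `COc1c(Cl)cc(NC(=O)Nc2cc(Cl)nc(Cl)c2)cc1Cl` gives 41500 nM

Both numbers come from a functional assay on HCT-116 cells (Homo sapiens) for inhibition, read by MTT assay, with a stated time of 72 h, in the presence of a further agent that is not named here (a higher number here means that more compound is needed for the effect, a lower number that less compound is needed), and compound 1 holds the lower of the two, so less of it is needed for the effect. The gap up to compound 2 lies beyond the usual scatter of such measurements.

Compound 3 `O=C(Nc1cc(Cl)nc(Cl)c1)Nc1cc(Cl)nc(OC2CCCC2)c1` has not yet been measured. Within the data shown here, its one change from compound 1 is cyclopentyloxy in place of hydrogen on an aromatic carbon. This carbon belongs to a six-membered aromatic ring with 1 nitrogen. It sits next to the ring nitrogen and meta to a chloro group.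

Among the measured compounds shown here, no measured pair in this assay shows what this change does, so no step beyond the scatter is expected, and neither direction can be favoured. The estimated step of a 1.2-fold lower number from compound 1 to compound 3 (0.06 log units; within the scatter) is accordingly small, but it remains uncertain. For compound 3 the estimate is 14000 nM with an expected range from 3500 nM to 45000 nM in this measurement.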

Compound 3, half-maximal effective concentration: 5120 nM
The estimate for compound 3 lay 2.7-fold (0.44 log units) above the measured number; the range from low to high includes it.
By their numbers in this assay, from the lowest: compound 3; then compound 1; then compound 2.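

In this assay, the carbon next to the ring nitrogen turns out to be a place where a large group can be added without losing the effect: cyclopentyloxy in place of hydrogen gives a 3.1-fold lower number from compound 1 to compound 3 (0.50 log units; beyond the scatter). Among these compounds, this is the first measured sign of what a substituent does at this carbon, and the change is modest but points towards less compound being needed. No measurement available here explains the lower number.

This single pair cannot separate the contribution of the oxygen attached to the ring from that of the five-membered carbon ring, and a methoxy group, a longer chain such as butoxy, or an amine at the same carbon would help to tell these apart. Among the compounds shown here, it also remains open whether cyclopentyloxy is close to the best group for this carbon, and whether adding it would lower the number in the same way on a core carrying different groups elsewhere, such as the one in compound 2.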